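Furan-2-yl to thiophen-3-yl on the methoxy compound

The source may report more compounds than this note shows. Statements on the series, on what has been measured and on what is new or still open speak of the compounds shown alone.

Values measured in a functional assay on HL-60 cells (Homo sapiens) for antiproliferative activity, read by XTT assay, with a stated time of 72 h (a higher number here means a weaker inhibitor, a lower number a stronger inhibitor), are these
compound 1 `C#Cc1cn([C@@H]2O[C@H](CO)[C@@H](O)[C@H]2O)c2ncnc(C)c12` gives 1110 nM
compound 2 `Nc1nc(N)c2c(-c3ccco3)cn([C@@H]3O[C@H](CO)[C@@H](O)[C@H]3O)c2n1` gives > 20000 nM (a limit)
compound 3 `COc1nc(N)nc2c1c(-c1ccco1)cn2[C@@H]1O[C@H](CO)[C@@H](O)[C@H]1O` gives > 20000 nM (a limit)

Compound 3 is known only as a limit (> 20000 nM). The picture around it is the limit of > 20000 nM in this assay, at which 2 of the 3 values shown sit, and compound 3 is one of those two. Going by the values given here, compound 1 is the only compound here with a number (1110 nM).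

Compound 4 `COc1nc(N)nc2c1c(-c1ccsc1)cn2[C@@H]1O[C@H](CO)[C@@H](O)[C@H]1O` differs from compound 3 in one place (thiophen-3-yl in place of furan-2-yl on an aromatic carbon), thiophen-3-yl in place of furan-2-yl on an aromatic carbon. Among the compounds with values here, the one measured step is a step that the two limits leave unreadable from compound 2 to compound 3 and it offers no size to carry over. That step is methoxy in place of amino on an aromatic carbon, so it does not touch the group changing here. Within the data shown here, no measured step replaces furan-2-yl.

With so little to go on, the expected outcome is a number no higher from compound 3 to compound 4 (the limit leaves the size open) with no step beyond the scatter expected in either direction. In this assay the estimated value for compound 4 is 20000 nM with an expected range from 8000 nM to 40000 nM and a report as a limit is likely.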

Compound 4, half-maximal inhibitory concentration: > 20000 nM
Compound 4: a limit, no number; the forecaster's own chance of this, stated with the estimate: 75%; the middle value lies on the limit itself.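

In this assay compound 3 and compound 4 are both known only as limits, so the step between them cannot be read. Compound 4 joins the group at the limit: the limit of > 20000 nM in this assay, at which 3 of the 4 values shown sit.

The compounds shown leave open whether thiophen-3-yl and furan-2-yl differ at all on the shared core.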